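The source may report more compounds than this note shows. Statements on the series, on what has been measured and on what is new or still open speak of the compounds shown alone.

Among the measured compounds shown here, compound 2 `COc1ccc(/C=C2\CCC/C(=C\c3ccc([N+](=O)[O-])cc3)C2=O)cc1OC` is the only member of this small set that yields a plain number: in a functional assay on HPC cells (Homo sapiens) for cytotoxicity (a lower number here means that less compound is tolerated, a higher number that more compound is tolerated), compound 2 gives 82000 nM. Compound 1 `COc1cc(/C=C2\CCC/C(=C\c3ccc([N+](=O)[O-])cc3)C2=O)ccc1O` reaches only the assay limit, > 400000 nM. Compound 3 `COc1ccc(/C=C2\Cc3ccccc3/C(=C\c3ccc([N+](=O)[O-])cc3)C2=O)cc1OC` likewise reaches only a limit, > 400000 nM. Two of the three results thus rest at the limit of > 400000 nM in this assay, at which 2 of the 3 values shown sit. For the measured compounds named here, the one step that can be sized, an at least 4.8-fold lower number from compound 1 to compound 2 (0.68 log units; beyond the scatter), lowered the number. Compound 4 `COc1cc(/C=C2\CCC/C(=C\c3ccc([N+](=O)[O-])cc3)C2=O)cc(OC)c1OC` carries, relative to compound 2, (methoxy in place of hydrogen on an aromatic carbon). Since the step of an at least 4.8-fold lower number from compound 1 to compound 2 (0.68 log units; beyond the scatter) also came from adding a methoxy, a further modest lowering of the number is expected, and the step from compound 2 to compound 4 is expected to be a 1.6-fold lower number from compound 2 to compound 4 (0.21 log units; within the scatter). Compound 4 is therefore estimated at 50000 nM, within a range from 15000 nM to 200000 nM.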

Compound 4, half-maximal cytotoxic concentration: 347000 nM
Beside the measured number, compound 4's estimate is 6.9-fold (0.84 log units) below it; the measured number lies above the stated range.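

On this aromatic ring, adding a methoxy does not always lower the number in this assay: the new result is a 4.2-fold higher number from compound 2 to compound 4 (0.63 log units; beyond the scatter). That runs opposite to the earlier change of a methyl in place of a hydrogen on an oxygen, which gave an at least 4.8-fold lower number from compound 1 to compound 2 (0.68 log units; beyond the scatter), so the direction of one change on this ring does not set the direction of the next. Nothing measured here accounts for this reversal.

Going by these compounds, it remains open whether a longer chain such as ethoxy, or an amine or a carboxylic acid, at this same place would also raise the number.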